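The source may report more compounds than this note shows. Statements on the series, on what has been measured and on what is new or still open speak of the compounds shown alone.

Compound 1 `C=C1C(=O)[C@]23C[C@@]1(O)CC[C@H]2c1ccc(O)c(C)c1[C@@H]3Cn1cc(-c2ccccc2)nn1` and compound 2 `C=C1C(=O)[C@]23C[C@@]1(O)CC[C@H]2c1ccc(O)c(C)c1[C@@H]3Cn1cc(-c2ccc(F)cc2)nn1` are built on the same core and differ in one place only: fluoro in place of hydrogen on an aromatic carbon. In a functional assay on SW480 cells (Homo sapiens) for cytotoxicity, read by MTT assay, with a stated time of 4 days (a lower number here means a stronger inhibitor, a higher number a weaker inhibitor), compound 1 gives 260 nM. In this assay compound 2 gives 250 nM. The step of a 1.0-fold lower number from compound 1 to compound 2 (0.02 log units; within the scatter) is too small to separate the two, so this change leaves the read-out essentially where it was.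

Compound 3 `C=C1C[C@]23C[C@@]1(O)CC[C@H]2c1cc(Br)c(O)c(C)c1[C@@H]3Cn1cc(-c2ccccc2)nn1` rests on a different core; the difference between the two cores is not broken down here. In this assay compound 3 reaches only a limit of the assay, > 20000 nM, and not a number. This is the limit of > 20000 nM in this assay, at which 1 of the 3 values shown sits, a ceiling rather than a measured value.

Compound 4 `C=C1C[C@]23C[C@@]1(O)CC[C@H]2c1cc(Br)c(O)c(C)c1[C@@H]3Cn1cc(-c2ccc(F)cc2)nn1` stands to compound 3 exactly as compound 2 stands to compound 1: fluoro in place of hydrogen on an aromatic carbon. The place is described in the same words for both pairs, so this is the same change, not merely the same kind. Since the fluoro for hydrogen swap gave a step within the scatter in the first pair, the expectation is that it changes little in the second pair as well, and that compound 4 will most likely again come back as a limit rather than a number.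

The step this estimate means, a step that the limit leaves unreadable from compound 3 to compound 4, is expected to be negligible because the same change gave a 1.0-fold lower number from compound 1 to compound 2 (0.02 log units; within the scatter).

Compound 4 is therefore estimated at about 40000 nM, with a plausible range from 15000 nM to 150000 nM.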

Compound 4, half-maximal inhibitory concentration: > 20000 nM
Compound 4: only a limit was reported; the forecaster's own chance of this, stated with the estimate: 85%; the middle value does not contradict the limit.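

In this assay compound 4 gives > 20000 nM, which is a limit of the assay and not a number. Compound 3 sits at this same limit, so no step from compound 3 to compound 4 can be read: the limit of > 20000 nM in this assay, at which 2 of the 4 values shown sit.

The compounds shown leave open whether fluoro in place of hydrogen changes the read-out on the core of compound 3, and where the true values of compound 3 and compound 4 lie.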